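A few compounds are considered here, and "the series" means these few. Any claim that something is new, unique, unknown or untested is made for them only; others in the source may bear on it.

Compound 1 `CCC(=O)N1c2ccccc2CCC1C(=O)Nc1ccccc1C(F)(F)F` was tested in a functional assay on PC-3 cells (Homo sapiens) for cytotoxicity, read by sulforhodamine B assay, with a stated time of 72 h; a higher number here means a weaker inhibitor of growth, a lower number a stronger inhibitor of growth. In this assay compound 1 gives > 80000 nM, which is a limit of the assay rather than a number; compound 1 thus sits at the limit of > 80000 nM in this assay, at which 1 of the 2 values shown sits. Compound 2 `CCC(=O)N1c2ccccc2CCC1C(=O)Nc1cc(C(F)(F)F)cc(C(F)(F)F)c1` gives 8540 nM in this assay. Compound 3 `CC(=O)N1c2ccccc2CCC1C(=O)Nc1ccccc1C(F)(F)F` is not yet measured; it differs from compound 1 by hydrogen in place of methyl on a saturated chain carbon bound to a carbonyl carbon. Such a small change is expected to move this assay by no step beyond the scatter, as a step that the limit leaves unreadable from compound 1 to compound 3. Compound 3 is therefore estimated at 90000 nM, between 40000 nM and 200000 nM, most likely again reported only as a limit.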

Compound 3, concentration for 50% growth inhibition: > 80000 nM
Compound 3: no number, only a limit (the forecaster's own chance of this, stated with the estimate: 75%); the middle value is on the limit's open side.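

Going by these compounds alone, compound 1 and compound 3 both stand only at a limit of the assay, so no step between them can be read: the limit of > 80000 nM in this assay, at which 2 of the 3 values shown sit.

The compounds shown leave open whether going from propanoyl to acetyl changes growth inhibition at all.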